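Sulfonyl pyridopyrimidinone series: amine replacement at the anilino position

The compounds below may be only part of what the source reports. "The series", "measured", "known", "first", "only" and "open" are said of these compounds alone.

Measured compounds:
Compound 1 `Cn1c(=O)c(S(=O)(=O)c2ccc(F)cc2F)cc2cnc(Nc3cccc4[nH]ccc34)nc21`: 750 nM
Compound 2 `Cn1c(=O)c(S(=O)(=O)c2ccc(Cl)cc2)cc2cnc(Nc3cccc4[nH]ccc34)nc21`: 5000 nM
Compound 3 `Cn1c(=O)c(S(=O)(=O)c2ccc(F)cc2)cc2cnc(Nc3cccc4[nH]ccc34)nc21`: 750 nM

In a functional assay on DU-145 cells (Homo sapiens) for inhibition, read by trypan blue exclusion, with a stated time of 72 h (on this read-out lower numbers stand for stronger inhibition and higher numbers for weaker inhibition), compound 1 sits level with compound 3, the two together at the lowest numbers among the three. Among the measured compounds shown here, the only measured steps concern the aryl group on the sulfonyl sulfur: a 6.7-fold higher number from compound 1 to compound 2 (0.82 log units; beyond the scatter), no change at the digits printed from compound 1 to compound 3 (within the scatter) and a 6.7-fold lower number from compound 2 to compound 3 (0.82 log units; beyond the scatter). The chloro-bearing compound 2 is the one that stands apart.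

Compound 4 `Cn1c(=O)c(S(=O)(=O)c2ccc(F)cc2F)cc2cnc(Nc3ccc4c(c3)C(=O)C(=O)N4)nc21` keeps the sulfonyl aryl of compound 1 and changes the other side: a group of 11 heavy atoms (8 carbon, 1 nitrogen, 2 oxygen; one five-membered non-aromatic ring with 1 hetero atom, one six-membered aromatic ring of carbon only) in place of a group of 9 heavy atoms (8 carbon, 1 nitrogen; one five-membered aromatic ring with 1 hetero atom, one six-membered aromatic ring of carbon only), on a nitrogen on an aromatic ring. For the measured compounds named here, no measured step touches this position; all three compounds carry the same 1H-indol-4-yl, so nothing in the set shows how this assay answers a change there. The expectation therefore rests on compound 1 alone, with a wide range: compound 4 is expected at 1500 nM, between 300 nM and 8000 nM. The step of a 2.0-fold higher number from compound 1 to compound 4 (0.30 log units; within the scatter) is an estimate with direction undetermined.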

Compound 4, half-maximal inhibitory concentration: 75000 nM
Compound 4: the middle estimate sits 50-fold (1.70 log units) below what was measured, outside the stated range (above it).
By their numbers in this assay, from the lowest: compounds 1 and 3 (each within the scatter of the next); then compound 2; then compound 4.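

In this assay the substituent on this nitrogen proves a sensitive position: the group of 11 heavy atoms in place of 1H-indol-4-yl gives a 100-fold higher number from compound 1 to compound 4 (2.00 log units; beyond the scatter) and so outweighs the step on the sulfonyl aryl, a 6.7-fold higher number from compound 1 to compound 2 (0.82 log units; beyond the scatter) in the earlier set. The entering group carries the same count of hydrogen-bond donors as the group it replaces, so keeping that count does not keep the number in this pair. Nothing available bears on why the number rises so far.

With a single replacement shown, the two carbonyls and the loss of the aromatic five-membered ring cannot be separated. Also open, from the compounds shown here alone, is how a simple phenyl or a 1H-indol-5-yl on this nitrogen would read, and whether the 4-fluorophenyl sulfone of compound 3 would answer this change in the same way.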